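The compounds below may be only part of what the source reports. "The series", "measured", "known", "first", "only" and "open" are said of these compounds alone.

Compound 1 `CCCc1nc(-c2ccccc2)c(CNCCN2CCN(c3ccccn3)CC2)o1`: 48.1%
Compound 2 `CCCc1nc(-c2ccccc2)c(CNCCN2CCN(c3ccccc3)CC2)o1`: 54.3%
Compound 3 `CCCc1nc(-c2ccccc2)c(CNCCN2CCN(c3ccccc3C)CC2)o1`: 51.3%

In an assay on HEK293 cells for inhibition of Voltage-dependent T-type calcium channel subunit alpha-1G (Homo sapiens), read by fluorescence, tested at 10 uM (on this read-out higher numbers stand for more inhibition at the one concentration tested (going by the name of the read-out) and lower numbers for less inhibition), the three measured compounds give numbers that all lie within the scatter of one another. Compound 3 sits between the other two, with a number 3 percentage points lower from compound 2 to compound 3 (within the scatter) and a number 3.2 percentage points higher from compound 1 to compound 3 (within the scatter).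

Compound 4 `CCCc1nc(-c2ccccc2)c(CNCCN2CCN(c3ccccc3OC)CC2)o1` differs from compound 3 by methoxy in place of methyl on an aromatic carbon. The step that bears most on this change is the one on the same aromatic carbon, a number 3 percentage points lower from compound 2 to compound 3 (within the scatter); the wider changes of the aryl group on the ring nitrogen, a number 6.2 percentage points higher from compound 1 to compound 2 (within the scatter) and a number 3.2 percentage points higher from compound 1 to compound 3 (within the scatter), were also within the scatter. Compound 4 is therefore expected to show a number 0.7 percentage points higher from compound 3 to compound 4 (within the scatter), no step beyond the scatter. The estimate for compound 4 is 52%, in the range 40% to 64%.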

Compound 4, a percentage reported as inhibition, at one concentration (the size of the read-out at that concentration, not a potency): 39.7%
Beside the measured number, compound 4's estimate is 12.3 percentage points above it; the whole stated range lies above it.
By their numbers in this assay, from the lowest: compounds 4, 1, 3 and 2 (each within the scatter of the next, the first and the last beyond it).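

In this assay, for the compounds shown here, the aromatic carbon ortho to a large group turns out to respond to what is placed on it: methyl stayed within the scatter of hydrogen, but methoxy gives the only steps beyond the scatter in this set (a number 11.6 percentage points lower from compound 3 to compound 4 (beyond the scatter); a number 14.6 percentage points lower from compound 2 to compound 4 (beyond the scatter)). Against the pyridin-2-yl group, the 2-methoxyphenyl group remains within the scatter (a number 8.4 percentage points lower from compound 1 to compound 4 (within the scatter)). No measurement shown explains the difference between methoxy and methyl.

Going by these compounds, whether a hydroxyl, an ethoxy or a chlorine on this carbon would behave like methyl or like methoxy remains open. With only one concentration shown, so does the size of the effect of these compounds at any other concentration.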